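A few compounds are considered here, and "the series" means these few. Any claim that something is new, unique, unknown or untested is made for them only; others in the source may bear on it.

Compound 1 `CC(=O)Nc1n[nH]c(=O)cc1-c1ccccc1` is one of two compounds tested in an assay for inhibition of casein kinase I isoform alpha (Sus scrofa), read by scintillation counting and 33P incorporation, with a stated time of 30 min, in the presence of a further agent that is not named here; a higher number here means a weaker inhibitor, a lower number a stronger inhibitor. In this assay compound 1 reaches only the limit of > 10000 nM. Compound 2 `CC(=O)N(C(C)=O)c1n[nH]c(=O)c2ccccc12` is the other, and in this assay compound 2 likewise reaches only the limit of > 10000 nM. So compound 2 stands at the limit of > 10000 nM in this assay, at which 2 of the 2 values shown sit, with no number of its own. Compound 3 `CC(=O)Nc1n[nH]c(=O)c2ccccc12` differs from compound 2 by hydrogen in place of acetyl on an amide-type nitrogen. Among the compounds with values here, no measured step guides this change; compound 3 is expected to sit near compound 2, a shift of a step that the limit leaves unreadable from compound 2 to compound 3 that stays within the scatter. Compound 3 is estimated at 15000 nM, between 3000 nM and 60000 nM.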

Compound 3, half-maximal inhibitory concentration: > 10000 nM
Compound 3: no number, only a limit; the forecaster's own chance of this, stated with the estimate: 75%; the middle value does not contradict the limit.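

Compound 2 and compound 3 each reach only a limit in this assay, so no step can be read between them: the limit of > 10000 nM in this assay, at which 3 of the 3 values shown sit. The compounds shown leave open which structural change, if any, would give a number rather than a limit in this assay.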